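Ethynyl to cyano on the aryl of compound 1

A few compounds are considered here, and "the series" means these few. Any claim that something is new, unique, unknown or untested is made for them only; others in the source may bear on it.

Of the compounds shown here, two have numbers so far. Compound 1 `C#Cc1ccc(-n2c(SC(C)c3ccccc3)nc3c(cnn3C)c2=O)cc1` gives 520 nM in an assay on isolated protein for inhibition of Retinaldehyde dehydrogenase 3 (Homo sapiens); on this read-out higher numbers stand for weaker inhibition and lower numbers for stronger inhibition. Compound 2 `Cn1ncc2c(=O)n(-c3ccccc3)c(OCc3cccc(F)c3)nc21` gives 1700 nM in this assay. Compound 1 therefore stands at the lowest number of the two, with compound 2 at a higher number, and that gap lies beyond the scatter.

Compound 3 `CC(Sc1nc2c(cnn2C)c(=O)n1-c1ccc(C#N)cc1)c1ccccc1` has not yet been measured. It differs from compound 1 in one place: cyano in place of ethynyl on an aromatic carbon. Among the measured compounds shown here, no measured pair isolates this change, so its size cannot be read from the data. Both groups carry a triple bond outside aromatic rings; the cyano brings one hydrogen-bond acceptor. The expected step from compound 1 to compound 3 is a 1.0-fold lower number from compound 1 to compound 3 (0.02 log units; within the scatter), small and not beyond the scatter in either direction. In this assay, the estimate for compound 3 is 500 nM, ranging from 200 nM to 1300 nM.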

Compound 3, half-maximal inhibitory concentration: 200 nM
Estimate against measurement, compound 3: 2.5-fold (0.40 log units) above, and the stated range covers the measured number.
By their numbers in this assay, from the lowest: compound 3; then compound 1; then compound 2.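

Swapping 4-ethynylphenyl for 4-cyanophenyl gives a 2.6-fold lower number from compound 1 to compound 3 (0.41 log units; beyond the scatter) in this assay, the first step in the series that isolates this position. The number of heavy atoms and the triple bond outside aromatic rings stay the same, and the entering cyano adds a hydrogen-bond acceptor, so this position responds to a change that leaves those counts almost untouched. No measurement at hand accounts for the step, and whether the added acceptor plays any part cannot be told.

Still open, as far as these compounds go, is whether a carboxylic acid, an amine or a methoxy group at this position would give a lower or higher number than cyano. Also open, from the compounds shown here alone, is whether the step would carry over to a compound with the fluorinated benzyl ether of compound 2.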